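One More Methyl on a Branched Chain

The source may hold more compounds than are shown below. What is called first, only, known or untested is meant among the compounds shown, and "the series" means these compounds.

In a functional assay on PC-3 cells (Homo sapiens) for antiproliferative activity, read by WST assay, with a stated time of 3 days (on this read-out higher numbers stand for weaker inhibition and lower numbers for stronger inhibition), compound 1 `CCCOc1c(-c2cc(OC)c(OC)c(OC)c2)oc2ccccc2c1=O` gives 11800 nM while compound 2 `CCCCCCOc1c(-c2cc(OC)c(OC)c(OC)c2)oc2ccccc2c1=O` gives 29200 nM and compound 3 `CCC(C)Oc1c(-c2cc(OC)c(OC)c(OC)c2)oc2ccccc2c1=O` gives 38600 nM on the same read-out. Compound 3 thus shares the high end of these numbers with compound 2, and compound 1 lies clearly lower. Compound 4 `CCCC(C)Oc1c(-c2cc(OC)c(OC)c(OC)c2)oc2ccccc2c1=O` differs from compound 3 by methyl in place of hydrogen on a saturated chain carbon, three bonds along the chain from an oxygen on an aromatic ring and this is methyl in place of hydrogen on a saturated chain carbon, three bonds along the chain from an oxygen on an aromatic ring. Two modest steps were seen, a 2.5-fold higher number from compound 1 to compound 2 (0.39 log units; beyond the scatter) and a 3.3-fold higher number from compound 1 to compound 3 (0.51 log units; beyond the scatter), yet a 1.3-fold higher number from compound 2 to compound 3 (0.12 log units; within the scatter) stayed small. So no step beyond the scatter is expected in this assay here. The expected change is a 1.2-fold lower number from compound 3 to compound 4 (0.07 log units; within the scatter) by this reasoning. The estimate for compound 4 is 33000 nM with an expected range from 15000 nM to 65000 nM at its upper end.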

Compound 4, half-maximal inhibitory concentration: 49300 nM
Estimate against measurement, compound 4: 1.5-fold (0.17 log units) below; the measured number falls inside the stated range.
By their numbers in this assay, from the lowest: compound 1; then compounds 2, 3 and 4 (each within the scatter of the next).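

In this assay the methyl that turns sec-butyl into 1-methylbutyl gives a 1.3-fold higher number from compound 3 to compound 4 (0.11 log units; within the scatter) and so does not move the number beyond the scatter at this chain position. Set against hexyl, 1-methylbutyl gives a 1.7-fold higher number from compound 2 to compound 4 (0.23 log units; within the scatter) and again stays within the scatter, while against propyl it gives a 4.2-fold higher number from compound 1 to compound 4 (0.62 log units; beyond the scatter) and lies beyond it. Nothing measured here explains these differences.

Still open, as far as these compounds go, is how an ethyl chain, or a chain ending in an amine or a carboxylic acid, would read on an oxygen on an aromatic ring.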